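Methoxy in place of methyl: compound 2 to compound 4

This account rests on a few compounds, and the source may have more. Where it says the series, first, only, none or still open, it means among the compounds named here.

Three compounds have numbers in an assay on LM cells with Alpha-1B adrenergic receptor (Homo sapiens) as the target; on this read-out lower numbers stand for stronger inhibition and higher numbers for weaker inhibition. Compound 1 `O=C1c2ccccc2C(=O)N1CCCCN1CCC(n2c(O)nc3ccccc32)CC1` gives 3 nM, compound 3 `Cc1cc(C)c2oc(=O)n(C3CCN(CCCCN4C(=O)c5ccccc5S4(=O)=O)CC3)c2c1` gives 108 nM, and compound 2 `Cc1ccc2c(c1)oc(=O)n2C1CCN(CCCCN2C(=O)c3ccccc3S2(=O)=O)CC1` gives 301 nM, the highest of the three and beyond the scatter from each of the other two. Compound 4 `COc1ccc2c(c1)oc(=O)n2C1CCN(CCCCN2C(=O)c3ccccc3S2(=O)=O)CC1` has not yet been measured in this assay. It differs from compound 2 in one place: methoxy in place of methyl on an aromatic carbon. Going by the values given here, no measured pair shows this exchange, so the size of the step rests on expectation alone. The step from compound 2 to compound 4 is expected to be small, in no direction beyond the scatter, estimated at a 1.4-fold lower number from compound 2 to compound 4 (0.14 log units; within the scatter). Compound 4 is therefore expected near 220 nM, within a range from 70 nM to 700 nM.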

Compound 4, inhibition constant: 1650 nM
For compound 4 the middle estimate is 7.5-fold (0.88 log units) below the measured one, outside the stated range (above it).
By their numbers in this assay, from the lowest: compound 1; then compound 3; then compound 2; then compound 4.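

This position, meta to a fused ring and para to a fused ring, is not indifferent to the group it carries: in this assay, methoxy in place of methyl gives a 5.5-fold higher number from compound 2 to compound 4 (0.74 log units; beyond the scatter). The exchange adds one heavy atom, an oxygen, and one hydrogen-bond acceptor, and it moves the number in the weaker direction. Nothing measured here accounts for the step.

A single pair cannot show whether the step follows the oxygen or the extra heavy atom. Ethyl or hydroxyl at this place would help separate the two.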